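Methoxy to Hydroxy: What to Expect for Compound 4

The compounds below may be only part of what the source reports. "The series", "measured", "known", "first", "only" and "open" are said of these compounds alone.

Compound 1, `COc1cc(/C=C2\Cc3ccccc3/C(=C\c3ccc([N+](=O)[O-])cc3)C2=O)ccc1O`, gives 5800 nM in a functional assay on HSG cells (Homo sapiens) for cytotoxicity; a lower number here means that less compound is tolerated, a higher number that more compound is tolerated.
Compound 2, `COc1ccc(/C=C2\Cc3ccccc3/C(=C\c3ccc([N+](=O)[O-])cc3)C2=O)cc1`, gives 47000 nM.
Compound 3, `COc1cc(/C=C2/C(=O)/C(=C/c3ccc([N+](=O)[O-])cc3)c3ccccc32)cc(OC)c1OC`, gives > 400000 nM, which is a limit of the assay rather than a number.

Of the two actual numbers, compound 2 stands highest, meaning it is the better tolerated of the pair; its nearest neighbour is compound 1, and the step between them is an 8.1-fold higher number from compound 1 to compound 2 (0.91 log units; beyond the scatter). For the measured compounds named here, that step is the one piece of measured evidence that bears on the next question, since it involves trading a free hydroxy group for a methylated one on the same aryl ring.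

Compound 4, `O=C1/C(=C/c2ccc(O)cc2)Cc2ccccc2/C1=C\c1ccc([N+](=O)[O-])cc1`, has not yet been measured. It differs from compound 2 by hydrogen in place of methyl on an oxygen on an aromatic ring. This reinstates a free phenol of the kind that compound 1 carries, so compound 4 is expected to move back toward compound 1, a step of about a 3.9-fold lower number from compound 2 to compound 4 (0.59 log units; beyond the scatter) in this assay. The estimate for compound 4 is therefore 12000 nM, with a plausible range from 4000 nM to 40000 nM.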

Compound 4, half-maximal cytotoxic concentration: 11000 nM
Compound 4: the middle estimate sits 1.1-fold (0.04 log units) above what was measured; the range from low to high includes it.
By their numbers in this assay, from the lowest: compounds 1 and 4 (each within the scatter of the next); then compound 2. At a limit, above all of these: compound 3.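

Taken alone, the swap of methyl for hydrogen on the oxygen gives a 4.3-fold lower number from compound 2 to compound 4 (0.63 log units; beyond the scatter) in this assay and so isolates the effect of 4-methoxyphenyl to 4-hydroxyphenyl, with no other part of the molecule altered. The earlier step, an 8.1-fold higher number from compound 1 to compound 2 (0.91 log units; beyond the scatter), changed two things on the ring at once, so it could not separate the free hydroxy group from the second methoxy group. The new comparison does separate them: hydrogen in place of methoxy on the aromatic carbon gives a 1.9-fold higher number from compound 1 to compound 4 (0.28 log units; within the scatter) and stays within the scatter, so that methoxy group makes no measurable difference here while the free hydroxy group is present.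

On these data alone, whether an amine or a carboxylic acid in place of the hydroxy group would give a similar number remains open. Nothing measured here explains why freeing the hydroxy group lowers the number.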